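Series notes: benzyl ether variation on the shared core

This account rests on a few compounds, and the source may have more. Where it says the series, first, only, none or still open, it means among the compounds named here.

Of the compounds shown here, two have been measured in a toxicity assay on Vero cells (Chlorocebus sabaeus) for cytotoxicity; on this read-out higher numbers stand for lower toxicity in this test and lower numbers for higher toxicity in this test. Compound 1 `O=C(/C=C/c1ccc([N+](=O)[O-])o1)c1ccc(Br)cc1` gives 354000 nM in this assay. Compound 2 `O=C(/C=C/c1ccc([N+](=O)[O-])o1)c1ccc(OCc2ccc(Cl)cc2Cl)cc1` gives 340000 nM in this assay. The two numbers sit within the scatter of each other, so compound 2 stands alongside compound 1 with no distinguishable separation between them on this read-out.

Compound 3 `O=C(/C=C/c1ccc([N+](=O)[O-])o1)c1ccc(OCc2cccc(Cl)c2)cc1` has not yet been measured in this assay. Relative to compound 2 the difference is 3-chlorophenyl in place of 2,4-dichlorophenyl on a saturated chain carbon bound to an oxygen on an aromatic ring. Within the data shown here, nothing measured so far speaks to the effect of changes at this position, since compound 1 carries a different group on the core and no pair in the set differs only there. Both measured compounds nonetheless sit at the same level in this assay. The step of no change at the digits printed from compound 2 to compound 3 (within the scatter) is expected to be none beyond the scatter. For compound 3 the estimated value in this assay is 340000 nM, with a range from 170000 nM to 680000 nM.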

Compound 3, half-maximal cytotoxic concentration: 307000 nM
Compound 3: the middle estimate sits 1.1-fold (0.04 log units) above what was measured; the range from low to high includes it.
By their numbers in this assay, from the lowest: compounds 3, 2 and 1 (each within the scatter of the next).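

Series notes, continued: in this assay, 3-chlorophenyl in place of 2,4-dichlorophenyl on a saturated chain carbon bound to an oxygen on an aromatic ring gives a 1.1-fold lower number from compound 2 to compound 3 (0.04 log units; within the scatter) and so provides the first pair in the set that differs only at this position; on this read-out, the two chlorophenyl patterns cannot be told apart. The second pair, with (3-chlorobenzyl)oxy in place of bromo on an aromatic carbon, gives a 1.2-fold lower number from compound 1 to compound 3 (0.06 log units; within the scatter) and shows that in this pair a single change of the whole group on the core also leaves no distinguishable separation. No supporting data are at hand that would account for this flat picture.

Both benzyl ethers shown carry only chlorine on the phenyl ring, so it remains open whether a primary amine or a carboxylic acid on that ring would give a step beyond the scatter on this read-out. Going by these compounds, it is equally open whether a longer chain in place of the single saturated carbon bound to the oxygen would stay level with these compounds.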